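The source may hold more compounds than are shown below. What is called first, only, known or untested is meant among the compounds shown, and "the series" means these compounds.

Compound 2 `Nc1nn(C(=O)Nc2ccc(Cc3ccccc3)cc2)c2ccc(Cl)cc12` gives 2900 nM in a functional assay on PC-3 cells (Homo sapiens) for antiproliferative activity, read by sulforhodamine B assay, with a stated time of 48 h (a lower number here means a stronger inhibitor of growth, a higher number a weaker inhibitor of growth), the lowest of the two numbers measured. Compound 1 `Nc1nn(C(=O)Nc2ccc(Cc3ccccc3)cc2)c2ccccc12` gives 13500 nM in this assay, and the step of a 4.7-fold lower number from compound 1 to compound 2 (0.67 log units; beyond the scatter) is the only one measured. Compound 3 `Nc1ccc2c(c1)c(N)nn2C(=O)Nc1ccc(Cc2ccccc2)cc1` differs from compound 2 by amino in place of chloro on an aromatic carbon. For the measured compounds named here, no measured step exchanges chloro for amino, so the only guide is that the step of a 4.7-fold lower number from compound 1 to compound 2 (0.67 log units; beyond the scatter) was modest. Compound 3 is expected to give up part of that gain, an estimated 2.8-fold higher number from compound 2 to compound 3 (0.44 log units; beyond the scatter). The estimate for compound 3 in this assay is 8000 nM, between 2500 nM and 25000 nM.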

Compound 3, concentration for 50% growth inhibition: 4330 nM
Estimate against measurement, compound 3: 1.8-fold (0.27 log units) above; low and high end bracket the measured number.
By their numbers in this assay, from the lowest: compounds 2 and 3 (each within the scatter of the next); then compound 1.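

At this aromatic carbon, a 1.5-fold higher number from compound 2 to compound 3 (0.17 log units; within the scatter) in this assay stays within the scatter, so amino and chloro cannot be told apart here, although amino brings a hydrogen-bond donor and acceptor that chloro lacks. Replacing hydrogen at this carbon is no longer a result for chloro alone, since a 3.1-fold lower number from compound 1 to compound 3 (0.49 log units; beyond the scatter) also lies beyond the scatter. Nothing available explains why these two groups read alike.

The compounds shown leave open whether a methoxy group, a hydroxyl group or an acetamide at this carbon would read alike. They also leave open whether chloro or amino on the other carbons of this ring would do the same.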